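The source may hold more compounds than are shown below. What is called first, only, known or untested is meant among the compounds shown, and "the series" means these compounds.

Measured compounds in a functional assay (strain AB) with Danio rerio as the target, read by microscopy, with a stated time of 1 h; a lower number here means that less compound is needed, a higher number that more compound is needed for the effect:
compound 1, `CCN1Cc2sc(NC(=O)Nc3ccc(Cl)cc3)c(C(N)=O)c2C1`, 4340 nM
compound 2, `NC(=O)c1c(NC(=O)Nc2ccc(Cl)cc2)sc2c1CCN(CC1CCCC1)C2`, 1830 nM
compound 3, `CCC(C)(C)C1CCc2c(sc(NC(=O)Nc3ccc(Cl)cc3)c2C(N)=O)C1`, > 25000 nM

All three share a urea-linked aminophenyl group and an amide on a fused core, differing in how the saturated part of that core is built and decorated. Compound 1 gives 4340 nM in this assay, and compound 2 gives 1830 nM. Compound 3 stands apart: its result is a limit, not a number, because it sits at the limit of > 25000 nM in this assay, at which 1 of the 3 values shown sits; the effect was not reached within the tested concentrations.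

Compound 4, `CCC1CCc2c(sc(NC(=O)Nc3ccc(Cl)cc3)c2C(N)=O)C1`, has not yet been tested. It differs from compound 3 in one place: ethyl in place of 1,1-dimethylpropyl on a saturated ring carbon. For the measured compounds named here, no measured pair here tracks this kind of exchange, so the expectation rests only on where compound 3 sits. A move back into the measurable range is possible, but the step could also vanish in the scatter or leave compound 4 at the limit as well.

Compound 4 is estimated at 15000 nM in this assay, with a likely range from 3000 nM to 50000 nM. That estimate would mean a step of an at least 1.6-fold lower number from compound 3 to compound 4 (0.22 log units; that floor lies within the scatter).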

Compound 4, half-maximal effective concentration: > 25000 nM
Compound 4 ended at the assay's limit; the forecaster's own chance of this, stated with the estimate: 40%; at least 1.6-fold (0.22 log units) between middle value and limit.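

In this assay, compound 3 and compound 4 both end at a limit rather than a number, so no step between them can be read: the limit of > 25000 nM in this assay, at which 2 of the 4 values shown sit.

The compounds shown leave open whether any group on that saturated ring carbon would give a readable number.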